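Halogen swap on the thiazole amide series, efficacy read-out

A few compounds are considered here, and "the series" means these few. Any claim that something is new, unique, unknown or untested is made for them only; others in the source may bear on it.

Of the compounds shown here, two have numbers so far. Compound 1 `COC(=O)c1cnc(NC(=O)[C@H](c2ccc(Cl)cc2)C(C)C)s1` carries an ester on the thiazole and, in a functional assay on CHO cells for agonist activity at Free fatty acid receptor 2 (Homo sapiens), read by cAMP accumulation (on this read-out higher numbers stand for larger maximal responses and lower numbers for smaller maximal responses), compound 1 gives 98%. Compound 2 `CC(C)(C)[C@H](C(=O)Nc1ncc(F)s1)c1ccc(Cl)cc1` replaces that ester with fluoro and a tert-butyl side chain; in this assay compound 2 gives 92%. The two values sit within the scatter of each other, so nothing is to be made of their order; both report a near-full maximal response. Compound 3 `CC(C)(C)[C@H](C(=O)Nc1ncc(Br)s1)c1ccc(Cl)cc1` has not been measured. It differs from compound 2 by bromo in place of fluoro on an aromatic carbon. Among the compounds with values here, no step between two measured compounds bears on this change, so the expectation rests only on the values of compound 1 and compound 2, both near the reference response. With both neighbours at that level, the step of no change at the digits printed from compound 2 to compound 3 (within the scatter) is expected to stay within the scatter, in either direction. Compound 3 is therefore estimated at 92% in this assay, with a range from 78% to 102%.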

Compound 3, largest response reached (reported as efficacy), in percent of the reference or control that the assay uses: 95%
The estimate for compound 3 lay 3 percentage points below the measured number, and the stated range covers the measured number.
By their numbers in this assay, from the lowest: compounds 2, 3 and 1 (each within the scatter of the next).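

In this assay, within the data shown here, the exchange of 5-fluoro-1,3-thiazol-2-yl for 5-bromo-1,3-thiazol-2-yl gives a number 3 percentage points higher from compound 2 to compound 3 (within the scatter), and this is the first step that isolates a single change at this position. On an aromatic carbon next to the ring sulfur and two ring bonds from the ring nitrogen, fluoro and bromo therefore cannot be told apart by maximal response, and both compounds keep the tert-butyl side chain and the shared core unchanged. Nothing at hand explains why the two halogens read alike.

From the compounds shown here alone, whether the same response holds with a group other than a halogen at this position, such as an amine, a nitrile or a carboxylic acid, remains open, as does the result with a plain hydrogen there. Also open, going by these compounds, is how the ester of compound 1 would read alongside the tert-butyl side chain of compound 2 and compound 3, since compound 1 differs from each of them in more than one place.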